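Thiophen-3-yl for furan-2-yl on the acyl thiourea carbonyl

This account rests on a few compounds, and the source may have more. Where it says the series, first, only, none or still open, it means among the compounds named here.

Working notes on the series. For the measured compounds named here, compound 2 `O=C(NC(=S)N1CCc2c(OCCCCCOc3ccc(Cl)cc3)cccc21)c1ccco1` is the only member with a number in an ADME assay on Huh-7 cells (Homo sapiens) for cytotoxicity; a lower number here means that less compound is tolerated, a higher number that more compound is tolerated; compound 2 gives 4620 nM there. Compound 1 `O=C(NC(=S)N1CCc2c(OCCCCCOc3ccc(Cl)cc3)cccc21)Oc1ccccc1` gives > 50000 nM in this assay, which is a limit of the assay and not a number (the limit of > 50000 nM in this assay, at which 1 of the 2 values shown sits). Between these two members the one measured step is an at least 10-fold lower number from compound 1 to compound 2 (1.03 log units; beyond the scatter), a large drop in tolerated concentration from the phenoxy to the furan-2-yl variant.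

Compound 3 `O=C(NC(=S)N1CCc2c(OCCCCCOc3ccc(Cl)cc3)cccc21)c1ccsc1` is not yet measured. The change from compound 2 is thiophen-3-yl in place of furan-2-yl on a carbonyl carbon. Going by the values given here, the only measured step that bears on this position, from compound 1 to compound 2, swapped a phenoxy for a heteroaryl ring; the present change keeps one five-membered aromatic ring with 1 hetero atom on the carbonyl carbon and exchanges oxygen for sulfur, a far smaller edit. Among the compounds with values here, no step here is expected beyond the scatter, and the step is estimated as a 1.2-fold lower number from compound 2 to compound 3 (0.06 log units; within the scatter). Compound 3 is expected to give about 4000 nM in this assay, in a range from 1500 nM to 12000 nM.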

Compound 3, half-maximal cytotoxic concentration: > 50000 nM
Compound 3 was reported as a limit; the forecaster's own chance of this, stated with the estimate: 5%; middle value at least 12-fold (1.09 log units) away from the limit.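

In this assay, keeping one five-membered aromatic ring with 1 hetero atom on the carbonyl carbon while exchanging furan-2-yl for thiophen-3-yl gives an at least 10-fold higher number from compound 2 to compound 3 (1.03 log units; beyond the scatter), so this position responds strongly to a change that leaves the heavy-atom, donor and acceptor counts as they were. The earlier step alone could have been read as applying to any such ring in place of phenoxy; compound 3 goes against that reading, and of the compounds shown only compound 2, the furan-2-yl member, gives a number rather than a limit. Compound 1 and compound 3 are both limits of the assay, so the step between them cannot be read, and they sit together: the limit of > 50000 nM in this assay, at which 2 of the 3 values shown sit.

The compounds shown leave open whether the lower number of compound 2 follows the ring oxygen or the point of attachment, a question that furan-3-yl and thiophen-2-yl on the same carbonyl carbon would separate. Also open, as far as these compounds go, is whether a pyridine ring or a plain alkyl chain at this place would stay at the limit.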